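A few compounds are considered here, and "the series" means these few. Any claim that something is new, unique, unknown or untested is made for them only; others in the source may bear on it.

Measured in a functional assay on MCF7 cells (Homo sapiens) for antiproliferative activity, read by CellTiter-Glo, with a stated time of 5 days; on this read-out higher numbers stand for weaker inhibition and lower numbers for stronger inhibition:

- Compound 1 `CC/C(=C(/c1ccc(/C=C/C(=O)O)cc1)c1ccc2ccccc2c1)c1ccccc1`: 180 nM
- Compound 2 `CC/C(=C(/c1ccc(/C=C/C(=O)O)cc1)c1ccc(-c2nccs2)cc1)c1ccccc1`: 290 nM

Compound 2, at 290 nM, lies within the usual scatter of compound 1, at 180 nM, so the two cannot be ranked against each other. Both sit in the same range of inhibition, and that range is the only reference point for what follows.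

The next compound is compound 3 `CC/C(=C(/c1ccc(/C=C/C(=O)O)cc1)c1ccc(N2CCN(C)CC2)cc1)c1ccccc1`. It carries 4-methylpiperazin-1-yl in place of 1,3-thiazol-2-yl on an aromatic carbon, para to a large group (4-methylpiperazin-1-yl in place of 1,3-thiazol-2-yl on an aromatic carbon). Among the compounds with values here, no measured pair differs in just one place, so the data give no direct size for such a change. The entering non-aromatic ring also has no counterpart in either measured compound, which leaves the expectation uncertain. A moderate move toward weaker inhibition in this assay is nevertheless expected, starting from the 290 nM of compound 2. The expected change is a 1.7-fold higher number from compound 2 to compound 3 (0.24 log units; within the scatter). The estimate for compound 3 is 500 nM, with an expected range from 120 nM to 2000 nM.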

Compound 3, half-maximal inhibitory concentration: 220 nM
Compound 3: middle estimate off by 2.3-fold (0.36 log units), on the high side; the range from low to high includes it.
By their numbers in this assay, from the lowest: compounds 1, 3 and 2 (each within the scatter of the next).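

In this assay, 4-methylpiperazin-1-yl in place of 1,3-thiazol-2-yl on an aromatic carbon gives a 1.3-fold lower number from compound 2 to compound 3 (0.12 log units; within the scatter), so the exchange cannot be told apart from repeat measurement. Within the data shown here, this is the first view of a non-aromatic ring at this place, on a six-membered aromatic ring of carbon only and para to a large group, and it shows that the five-membered aromatic ring can give way to a larger six-membered non-aromatic ring with no resolved difference in antiproliferative read-out. Nothing available accounts for this outcome.

The compounds shown leave open whether the tolerance extends to other groups at this place, such as morpholin-4-yl, piperazin-1-yl without its methyl, an open-chain dimethylamino group or a plain hydrogen. They also leave open whether any group here can move the read-out beyond the scatter, and whether the same exchange would behave alike if the carboxylic acid of the shared core gave way to an ester or an amide.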